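The source may hold more compounds than are shown below. What is called first, only, known or untested is meant among the compounds shown, and "the series" means these compounds.

Compound 1 `Oc1ccc(C(c2c[nH]c3ccc(Br)cc23)c2c[nH]c3ccc(Br)cc23)cc1`: 4000 nM
Compound 2 `COc1ccc(C(c2c[nH]c3ccc(Br)cc23)c2c[nH]c3ccc(Br)cc23)cc1`: 5500 nM
Compound 3 `COc1ccc(OC)c(C(c2c[nH]c3ccc(Br)cc23)c2c[nH]c3ccc(Br)cc23)c1`: 5100 nM

In a functional assay on HeLa cells (Homo sapiens) for inhibition, read by MTT assay, with a stated time of 48 h (on this read-out higher numbers stand for weaker inhibition and lower numbers for stronger inhibition), compound 2, at 5500 nM, cannot be told apart from the other two compounds: a 1.4-fold higher number from compound 1 to compound 2 (0.14 log units; within the scatter) and a 1.1-fold lower number from compound 2 to compound 3 (0.03 log units; within the scatter). Compound 4 `Brc1ccc2[nH]cc(C(c3c[nH]c4ccc(Br)cc34)C3CCCCC3)c2c1` follows from compound 2 through one change: cyclohexyl in place of 4-methoxyphenyl on a saturated chain carbon bound to two aromatic carbons. The nearest evidence comes from the swaps of one aromatic group for another at this carbon, a 1.3-fold higher number from compound 1 to compound 3 (0.11 log units; within the scatter) and again a 1.1-fold lower number from compound 2 to compound 3 (0.03 log units; within the scatter), and neither moved the number beyond the scatter. Going by the values given here, no measured compound carries a non-aromatic ring there, so the evidence reaches this change only loosely. The expected result is therefore no shift beyond the scatter, an estimated 1.1-fold lower number from compound 2 to compound 4 (0.04 log units; within the scatter). For compound 4 the estimated value is 5000 nM, with an expected range of 2000 nM to 12000 nM.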

Compound 4, half-maximal inhibitory concentration: 3200 nM
Compound 4: the middle estimate sits 1.6-fold (0.19 log units) above what was measured, and the stated range covers the measured number.
By their numbers in this assay, from the lowest: compounds 4, 1, 3 and 2 (each within the scatter of the next).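

Putting cyclohexyl, a six-membered non-aromatic ring of carbon only, on this saturated chain carbon kept the number within the scatter of all three aromatic-substituted compounds (a 1.7-fold lower number from compound 2 to compound 4 (0.24 log units; within the scatter); a 1.6-fold lower number from compound 3 to compound 4 (0.20 log units; within the scatter); a 1.3-fold lower number from compound 1 to compound 4 (0.10 log units; within the scatter)). The earlier compounds showed this only for aromatic groups; compound 4 shows that, among these four compounds, an aromatic ring at this carbon is not needed for a number in this range. Nothing at hand bears on what lies behind this result.

On these data alone, whether an amine, a carboxylic acid or a longer chain at this carbon would move the number beyond the scatter remains open.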